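Extending the Amine End of Compound 2

The source may hold more compounds than are shown below. What is called first, only, known or untested is meant among the compounds shown, and "the series" means these compounds.

Three measured compounds share one core and differ only in the group attached through the carbonyl carbon. Compound 1 `COC(=O)c1c(O)c2ccccc2n(-c2ccccc2)c1=O` carries a methoxy there, and in a functional assay, with a stated time of 20 min, tested at 0.5 mM (on this read-out higher numbers stand for a stronger effect at the one concentration tested and lower numbers for a weaker effect), compound 1 gives 16.8%. Compound 2 `NCCCCCCNC(=O)c1c(O)c2ccccc2n(-c2ccccc2)c1=O` gives 19.3%, and compound 3 `Nc1ccccc1NC(=O)c1c(O)c2ccccc2n(-c2ccccc2)c1=O` gives 21.3%. The second highest of the three numbers belongs to compound 2. The nearest of the other two lies a number 2 percentage points higher from compound 2 to compound 3 (within the scatter); the furthest lies a number 2.5 percentage points higher from compound 1 to compound 2 (within the scatter). The remaining step, a number 4.5 percentage points higher from compound 1 to compound 3 (within the scatter), is likewise within the scatter, so the three compounds cannot be told apart on this read-out.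

Compound 4 `O=C(CCCCC1CCSS1)NCCCCCCNC(=O)c1c(O)c2ccccc2n(-c2ccccc2)c1=O` differs from compound 2 by a group of 11 heavy atoms (8 carbon, 1 oxygen, 2 sulfur; one five-membered non-aromatic ring with 2 hetero atoms) in place of a hydrogen atom, on an amine nitrogen. Going by the values given here, none of the measured steps touches this amine nitrogen; each swaps the group on the carbonyl carbon or the amide-type nitrogen, and each stays within the scatter. They thus give no sign of a change beyond the scatter in this assay, only weak guidance. The expected step is a number 0.3 percentage points lower from compound 2 to compound 4 (within the scatter), that is, none beyond the scatter. The estimate for compound 4 is 19%, expected to fall between 8% and 32%.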

Compound 4, a percentage reported as activity, at one concentration (the size of the read-out at that concentration, not a potency): 23.9%
Estimate against measurement, compound 4: 4.9 percentage points below, and the stated range covers the measured number.
By their numbers in this assay, from the lowest: compounds 1, 2, 3 and 4 (each within the scatter of the next).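

In this assay, putting the group of 11 heavy atoms on the amine nitrogen in place of a hydrogen atom gives a number 4.6 percentage points higher from compound 2 to compound 4 (within the scatter) and so no change that can be told from the scatter. Going by these compounds alone, this is the first information on that nitrogen, as the earlier steps all changed the group on the carbonyl carbon or the amide-type nitrogen, and it shows that a group of this size, with its five-membered non-aromatic ring with 2 hetero atoms, can replace the hydrogen atom there without a clear shift in the read-out. No measurement is available that would explain this result.

On these data alone, it remains open whether a plain acetyl group or an octanoyl chain without the sulfur-containing ring would read the same on this nitrogen. The same holds for this group on the amine of the 2-aminophenyl compound 3.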